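Cytotoxicity at the limit: a biaryl swap in an amide series

A few compounds are considered here, and "the series" means these few. Any claim that something is new, unique, unknown or untested is made for them only; others in the source may bear on it.

Measured compounds:
Compound 1 `CC(C)N(Cc1cccc(OCCCCCC(=O)O)c1)C(=O)c1ccc(-c2cccc(OCc3ccccc3)c2)cc1`: > 26000 nM
Compound 2 `CCOC(=O)CCCCCOc1cccc(CN(C(=O)c2ccc(-c3cccnc3)cc2)C(C)C)c1`: > 26000 nM

In an ADME assay on BJ cells (Homo sapiens) for cytotoxicity, read by CellTiter-Glo and resazurin assay, with a stated time of 72 h (a lower number here means that less compound is needed, a higher number that more compound is needed for the effect), compound 1 reaches only the limit of the assay, > 26000 nM. Compound 2 likewise gives only a limit, > 26000 nM. Both measured values therefore sit at the same point, as the limit of > 26000 nM in this assay, at which 2 of the 2 values shown sit, shows. Compound 3 `CCOC(=O)CCCCCOc1cccc(CN(C(=O)c2ccc(-c3cccc(OC(F)(F)F)c3)cc2)C(C)C)c1` differs from compound 2 by 3-(trifluoromethoxy)phenyl in place of pyridin-3-yl on an aromatic carbon. For the measured compounds named here, with no measured step to lean on and both values at the limit, no change beyond the usual scatter is expected in this assay from compound 2 to compound 3, a step that the limit leaves unreadable from compound 2 to compound 3. Compound 3 is accordingly estimated at 30000 nM, within 10000 nM to 100000 nM.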

Compound 3, half-maximal effective concentration: > 26000 nM
Compound 3 was reported as a limit; the forecaster's own chance of this, stated with the estimate: 70%; the middle value is on the limit's open side.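

Compound 3, like compound 2, gives only a limit in this assay, so no step can be read from compound 2 to compound 3. The compounds shown leave open whether any change among them shifts this read-out, as all sit at one point: the limit of > 26000 nM in this assay, at which 3 of the 3 values shown sit.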